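Methoxy for Fluoro on the Outer Phenyl Ring

The compounds below may be only part of what the source reports. "The series", "measured", "known", "first", "only" and "open" are said of these compounds alone.

Compound 3 `C=C(Br)C(=O)Nc1cccc(-c2cn3nc(-c4ccc(F)cc4)sc3n2)c1` gives 830 nM in a functional assay on CCRF-CEM cells (Homo sapiens) for inhibition, read by cell counting, with a stated time of 3 days; a lower number here means a stronger inhibitor, a higher number a weaker inhibitor. Among the three measured compounds it holds the second highest number: compound 1 `C=C(Br)C(=O)Nc1cccc(-c2cn3nc(-c4ccc(OC)c(OC)c4)sc3n2)c1` gives 380 nM, a step of a 2.2-fold higher number from compound 1 to compound 3 (0.34 log units; beyond the scatter), while compound 2 `C=C(Br)C(=O)Nc1cccc(-c2cn3nc(-c4ccc(OCC)cc4)sc3n2)c1` gives 1400 nM, a step of a 1.7-fold lower number from compound 2 to compound 3 (0.23 log units; within the scatter). Compound 4 `C=C(Br)C(=O)Nc1cccc(-c2cn3nc(-c4ccc(OC)cc4)sc3n2)c1` differs from compound 3 by methoxy in place of fluoro on an aromatic carbon. The step of a 1.7-fold lower number from compound 2 to compound 3 (0.23 log units; within the scatter) swaps an alkoxy group for fluoro, the reverse direction of the present change, and bears most directly on it; the step of a 3.7-fold higher number from compound 1 to compound 2 (0.57 log units; beyond the scatter) shows that alkoxy changes on this ring move the number only modestly. The step of a 1.0-fold lower number from compound 3 to compound 4 (0.02 log units; within the scatter) is therefore the expected outcome, nothing beyond the scatter. The estimate for compound 4 is 800 nM, within 350 nM to 1800 nM.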

Compound 4, half-maximal inhibitory concentration: 1200 nM
Beside the measured number, compound 4's estimate is 1.5-fold (0.18 log units) below it; the range from low to high includes it.
By their numbers in this assay, from the lowest: compound 1; then compounds 3, 4 and 2 (each within the scatter of the next).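

At this position, this assay does not separate fluoro from methoxy, with a 1.4-fold higher number from compound 3 to compound 4 (0.16 log units; within the scatter) as the step between them. Shortening ethoxy to methoxy also stays small, with a 1.2-fold lower number from compound 2 to compound 4 (0.07 log units; within the scatter) for that change. Removing one methoxy from the 3,4-dimethoxyphenyl group of compound 1 gives a 3.2-fold higher number from compound 1 to compound 4 (0.50 log units; beyond the scatter) and is the larger change of the three.

From the compounds shown here alone, whether an amine, a carboxylic acid or a longer chain such as butoxy at this position would stay in the same range remains open. No accompanying measurement bears on what lies behind these numbers.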